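The compounds below may be only part of what the source reports. "The series", "measured", "known", "first", "only" and "open" are said of these compounds alone.

The series is judged in a functional assay on HOS-TE85 cells (Homo sapiens) for inhibition, read by CCK-8 assay, with a stated time of 72 h; a lower number here means a stronger inhibitor, a higher number a weaker inhibitor. Compound 1 `COc1ccc(OC)c(N2C(=O)CSC2c2cccc(C(=O)NCCCCc3ccccc3)c2)c1` returns only a limit in this assay, > 1000 nM, so where it stands among the shown numbers is known only as a bound. Among the measured compounds shown here, it is the single value that sits at the limit of > 1000 nM in this assay, at which 1 of the 3 values shown sits. Compound 2 `O=C(NCCCCc1ccccc1)c1cccc(C2OCC(=O)N2c2cccc(F)c2)c1` gives 320 nM in this assay. Compound 3 `O=C(NCCCCn1cccn1)c1cccc(C2SCC(=O)N2c2cc(Br)ccn2)c1` gives 105 nM in this assay. No two of these three differ in one place, so their values are read side by side and nothing more.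

Compound 4 `Cc1cccc(N2C(=O)CSC2c2cccc(C(=O)NCCCCc3ccccc3)c2)c1` is not yet measured. It differs from compound 1 in one place: 3-methylphenyl in place of 2,5-dimethoxyphenyl on an amide-type nitrogen in a ring. Compound 2, with its value of 320 nM, shows that the shared core can reach a measured number with another group on the amide-type nitrogen in the ring. In this assay compound 4 is expected to give about 500 nM, within a range from 150 nM to 2000 nM. The expected step of an at least 2.0-fold lower number from compound 1 to compound 4 (0.30 log units; that floor lies within the scatter) is a gain beyond the scatter, though its true size cannot be fixed because compound 1 stands at the limit of > 1000 nM in this assay, at which 1 of the 3 values shown sits.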

Compound 4, half-maximal inhibitory concentration: 93.2 nM
Compound 4: middle estimate off by 5.4-fold (0.73 log units), on the high side; the measured number lies below the stated range.
By their numbers in this assay, from the lowest: compounds 4 and 3 (each within the scatter of the next); then compound 2. At a limit, above all of these: compound 1.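

Among the compounds shown here, for the first time, the shared core is held fixed while only the group on the amide-type nitrogen in the ring changes, and in this assay 3-methylphenyl in place of 2,5-dimethoxyphenyl gives an at least 10-fold lower number from compound 1 to compound 4 (1.03 log units; beyond the scatter). The position therefore responds strongly to the group it carries, although this one change removes the methoxy groups and adds the methyl together, so the pair cannot say which of these matters. The true size of the step stays unfixed because compound 1 is known only through a limit: the limit of > 1000 nM in this assay, at which 1 of the 4 values shown sits.

On these data alone, whether the gain comes from the methyl or from losing the methoxy groups remains open. So does how an amine or a carboxylic acid in place of the methyl on this phenyl ring would read in this assay.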